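Compound 3: a phenyl swap on compound 2

This account rests on a few compounds, and the source may have more. Where it says the series, first, only, none or still open, it means among the compounds named here.

In a functional assay on A549 cells (Homo sapiens) for cytotoxicity, read by MTT assay (on this read-out lower numbers stand for stronger inhibition and higher numbers for weaker inhibition), compound 1 (`CCn1cc(-c2nnc(COc3ccc4ccccc4c3)o2)c(=O)c2cc(F)c(N3CCNCC3)cc21`) gives 80.2 ug/mL while compound 2 (`O=c1c(-c2nnc(COc3ccc4ccccc4c3)o2)cn(C2CC2)c2cc(N3CCNCC3)c(F)cc12`) gives 16 ug/mL and so holds the lower of the two numbers. Compound 3 (`O=c1c(-c2nnc(Cc3ccccc3)o2)cn(C2CC2)c2cc(N3CCNCC3)c(F)cc12`) carries phenyl in place of (naphthalen-2-yl)oxy on a saturated chain carbon bound to an aromatic carbon. Among the compounds with values here, the one measured step (a 5.0-fold lower number from compound 1 to compound 2 (0.70 log units; beyond the scatter)) is cyclopropyl in place of ethyl on an aromatic nitrogen, a different change, so it hints only at a likely scale. The step expected in this assay is a 1.8-fold higher number from compound 2 to compound 3 (0.24 log units; within the scatter) as an estimate only. Its direction remains uncertain. The estimate for compound 3 is 28 ug/mL with 8 ug/mL to 90 ug/mL as its expected range.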

Compound 3, half-maximal inhibitory concentration: 86 ug/mL
Compound 3: the middle estimate sits 3.1-fold (0.49 log units) below what was measured; low and high end bracket the measured number.
By their numbers in this assay, from the lowest: compound 2; then compounds 1 and 3 (each within the scatter of the next).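

In this assay, phenyl in place of (naphthalen-2-yl)oxy gives a 5.4-fold higher number from compound 2 to compound 3 (0.73 log units; beyond the scatter), showing that the group on this saturated chain carbon, and not only the substituent on the aromatic nitrogen, moves the read-out beyond the scatter. The change removes both the oxygen and one of the two aromatic rings, so the shift cannot be assigned to either alone. No evidence is available to explain this shift. Phenoxy, which keeps the oxygen with a single ring, would separate the two, and naphthalen-2-yl, which keeps both rings without the oxygen, remains open too.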